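Replacing the fluoropyridine with a thiazole ring

The source may report more compounds than this note shows. Statements on the series, on what has been measured and on what is new or still open speak of the compounds shown alone.

Among the measured compounds shown here, compound 2 `O=C(CN1CCN(c2ccc(F)cn2)CC1)Nc1nc2c(s1)CCCC2` gives 600 nM in an assay on isolated protein for inhibition of long-chain fatty acid transport protein 1 (Mus musculus), read by scintillation counting, with a stated time of 20 min (on this read-out lower numbers stand for stronger inhibition and higher numbers for weaker inhibition), the only full number in this set. Compound 1 `O=C(CN1CCN(c2ccncc2)CC1)Nc1nc2c(s1)CCCC2` reaches only the assay limit, > 10000 nM (the limit of > 10000 nM in this assay, at which 1 of the 2 values shown sits). For the measured compounds named here, the single measured step, an at least 16-fold lower number from compound 1 to compound 2 (1.22 log units; beyond the scatter), alters the same aryl group that the step to compound 3 changes, showing that the group at this position strongly affects this assay. Compound 3 `O=C(CN1CCN(c2nccs2)CC1)Nc1nc2c(s1)CCCC2` differs from compound 2 by 1,3-thiazol-2-yl in place of 5-fluoropyridin-2-yl on an amine nitrogen in a ring. Going by the values given here, no measured pair guides a 1,3-thiazol-2-yl here, so a moderate weakening is expected. Compound 3 is estimated at 1500 nM (range 400 nM to 6000 nM), an expected step of a 2.5-fold higher number from compound 2 to compound 3 (0.40 log units; beyond the scatter).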

Compound 3, half-maximal inhibitory concentration: 7900 nM
For compound 3 the middle estimate is 5.3-fold (0.72 log units) below the measured one; the measured number lies above the stated range.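

In this assay, the change reads a 13-fold higher number from compound 2 to compound 3 (1.12 log units; beyond the scatter), so the 1,3-thiazol-2-yl does not retain what the 5-fluoropyridin-2-yl gives on this amine nitrogen in a ring, and not every aromatic ring here matches the fluoropyridine. Against the pyridin-4-yl, the step reads an at least 1.2-fold lower number from compound 1 to compound 3 (0.10 log units; that floor lies within the scatter), which does not separate these two groups. Compound 1 stands at a limit, not a number: the limit of > 10000 nM in this assay, at which 1 of the 3 values shown sits.

The compounds shown leave open whether a phenyl, a pyrimidin-2-yl or a 5-chloropyridin-2-yl on this nitrogen would match compound 2, and whether the fluorine itself matters.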